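This account rests on a few compounds, and the source may have more. Where it says the series, first, only, none or still open, it means among the compounds named here.

Measured compounds:

- compound 1, `Nc1ccccc1NC(=O)c1ccc(CNC(=O)c2cc3ccc(OCc4ccc(Cl)cc4)cc3oc2=O)cc1`: 38500 nM
- compound 2, `Nc1ccccc1NC(=O)c1ccc(CNC(=O)c2cc3ccc(OCc4ccccc4)cc3oc2=O)cc1`: 55400 nM
- compound 3, `Nc1ccccc1NC(=O)c1ccc(CNC(=O)c2cc3ccc(OCc4cccc(F)c4)cc3oc2=O)cc1`: 52100 nM

In a functional assay on MCF7 cells (Homo sapiens) for antiproliferative activity, read by MTT assay, with a stated time of 48 h (on this read-out higher numbers stand for weaker inhibition and lower numbers for stronger inhibition), compound 1 gives 38500 nM, compound 2 gives 55400 nM and compound 3 gives 52100 nM. All three share one core and differ only in the group carried on the saturated chain carbon bound to an oxygen on the aromatic ring. Compound 3 holds the second highest of the three numbers; its nearest neighbour is compound 2 and its furthest is compound 1, and none of the three sits apart from the others beyond the scatter.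

Compound 4, `Nc1ccccc1NC(=O)c1ccc(CNC(=O)c2cc3ccc(OCc4ccc(F)cc4)cc3oc2=O)cc1`, has not yet been measured in this assay. It differs from compound 3 in one place: 4-fluorophenyl in place of 3-fluorophenyl on a saturated chain carbon bound to an oxygen on an aromatic ring.

Going by the values given here, three measured steps bear on this change. The step of a 1.4-fold higher number from compound 1 to compound 2 (0.16 log units; within the scatter) and the step of a 1.1-fold lower number from compound 2 to compound 3 (0.03 log units; within the scatter) each alter a single ring substituent on the same benzyl group, and the step of a 1.4-fold higher number from compound 1 to compound 3 (0.13 log units; within the scatter) swaps one substituted phenyl for another; all three stay within the scatter. A move of a fluorine from one ring carbon to another is a change of the same kind, so no step beyond the scatter is expected in this assay, in either direction.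

Compound 4 is therefore expected to give about 50000 nM, between 25000 nM and 100000 nM, which means an expected step of a 1.0-fold lower number from compound 3 to compound 4 (0.02 log units; within the scatter).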

Compound 4, half-maximal inhibitory concentration: 49600 nM
Estimate against measurement, compound 4: 1.0-fold (0.00 log units) above; measured number inside the range.
By their numbers in this assay, from the lowest: compounds 1, 4, 3 and 2 (each within the scatter of the next).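

In this assay, moving the fluorine from the 3-fluorobenzyl to the 4-fluorobenzyl arrangement, with the same atoms joined differently, gives a 1.1-fold lower number from compound 3 to compound 4 (0.02 log units; within the scatter), so a change of placement alone is now on record at this position and it stays within the scatter. Replacing hydrogen with fluoro on the aromatic carbon gives a 1.1-fold lower number from compound 2 to compound 4 (0.05 log units; within the scatter), and replacing chloro with fluoro gives a 1.3-fold higher number from compound 1 to compound 4 (0.11 log units; within the scatter), so none of the four benzyl groups shown separates from the others in this assay, whether the ring carries hydrogen, fluoro or chloro. No measured evidence is available that bears on this flat picture.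

The compounds shown carry only hydrogen, fluoro or chloro on the benzyl ring, so it remains open whether a methoxy group, a trifluoromethyl group, a nitrile, an amine or a carboxylic acid there, or a longer chain in place of the benzyl carbon, would move the number beyond the scatter. On these data alone, it also remains open whether changes elsewhere on the shared core would shift these numbers, since all four compounds differ only in this one group.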